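The compounds below may be only part of what the source reports. "The series", "measured", "known", "first", "only" and "open" are said of these compounds alone.

In a functional assay (aorta) with Rattus norvegicus as the target (a lower number here means that less compound is needed, a higher number that more compound is needed for the effect), three compounds built on one shared core have been measured. Compound 1 (`COc1ccc(-c2nc(/N=C(\N)NC(C)C)sc2-c2ccc(OC)cc2)cc1`) gives 9.1 uM, compound 2 (`C/N=C(/NC)Nc1nc(-c2ccc(OC)cc2)c(-c2ccc(OC)cc2)s1`) gives 2.4 uM, and compound 3 (`COc1ccc(-c2nc(CN(C)C)sc2-c2ccc(OC)cc2)cc1`) gives 8.4 uM. Compound 3 stands level with compound 1, as a 1.1-fold lower number from compound 1 to compound 3 (0.03 log units; within the scatter) shows. Compound 2 lies apart from it, with a 3.5-fold higher number from compound 2 to compound 3 (0.54 log units; beyond the scatter).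

Compound 4 (`COc1ccc(-c2nc(CN)sc2-c2ccc(OC)cc2)cc1`) comes from compound 3 by a single change, amino in place of dimethylamino on a saturated chain carbon bound to an aromatic carbon. Within the data shown here, no measured step makes this exact exchange. The closest evidence is the three exchanges of a whole group on an aromatic carbon, which include the two above and a 3.8-fold lower number from compound 1 to compound 2 (0.58 log units; beyond the scatter). None of these exceeds a modest size, and they do not share a direction, so they offer no firm guide to the sign of the new step. In this assay, a step beyond the scatter is therefore not expected, although a modest one either way remains possible. The estimated step is a 1.2-fold lower number from compound 3 to compound 4 (0.08 log units; within the scatter). For compound 4 the expected value is 7 uM, with an estimated range from 2.5 uM to 20 uM.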

Compound 4, concentration for half-maximal effect: 7.7 uM
Compound 4: middle estimate off by 1.1-fold (0.04 log units), on the low side; low and high end bracket the measured number.
By their numbers in this assay, from the lowest: compound 2; then compounds 4, 3 and 1 (each within the scatter of the next).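

At this position in this assay, the number does not respond to the change from dimethylamino to amino on a saturated chain carbon bound to an aromatic carbon (a 1.1-fold lower number from compound 3 to compound 4 (0.04 log units; within the scatter)), even though the two groups differ in heavy atoms and in hydrogen-bond donors. Compound 4 also sits level with the compound carrying the larger group on an aromatic carbon (a 1.2-fold lower number from compound 1 to compound 4 (0.07 log units; within the scatter)), so compounds 1, 3 and 4 form one group despite their different substituents, whereas compound 2 goes against this pattern and stays apart (a 3.2-fold higher number from compound 2 to compound 4 (0.51 log units; beyond the scatter)). Nothing given here explains why these groups are interchangeable or why compound 2 differs.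

As far as these compounds go, it remains open whether this tolerance extends beyond simple amines on the chain carbon, for example to a hydroxyl, a carboxylic acid or a piperidine ring in place of amino. The compounds shown also leave open whether a longer chain between the aromatic carbon and the amino group would keep the number at this level or bring it closer to that of compound 2.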